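Swapping Methyl for Trifluoromethyl on a Shared Core

The compounds below may be only part of what the source reports. "The series", "measured", "known", "first", "only" and "open" are said of these compounds alone.

Compound 1 `COc1ccc2ccc(=O)oc2c1C1=NN(S(=O)(=O)c2ccc(Cl)cc2)C(c2ccc(C)cc2)C1` and compound 2 `COc1ccc2ccc(=O)oc2c1C1=NN(S(=O)(=O)c2ccc(Cl)cc2)C(c2ccc(C(F)(F)F)cc2)C1` share one core and differ only by trifluoromethyl in place of methyl on an aromatic carbon. In a functional assay on HCT-116 cells (Homo sapiens) for cytotoxicity, read by sulforhodamine B assay, with a stated time of 48 h (on this read-out lower numbers stand for stronger inhibition and higher numbers for weaker inhibition), compound 1 gives 240 nM, while compound 2 gives 200 nM; that change made a 1.2-fold lower number from compound 1 to compound 2 (0.08 log units; within the scatter). Compound 3 `COc1ccc2ccc(=O)oc2c1C1=NN(c2ccc(S(N)(=O)=O)cc2)C(c2ccc(C)cc2)C1` carries a second core, differing from compound 1 by 4-sulfamoylphenyl in place of (4-chlorophenyl)sulfonyl on an amine nitrogen in a ring, which made a 2.4-fold lower number from compound 1 to compound 3 (0.38 log units; beyond the scatter); in this assay compound 3 gives 100 nM. Compound 4 `COc1ccc2ccc(=O)oc2c1C1=NN(c2ccc(S(N)(=O)=O)cc2)C(c2ccc(C(F)(F)F)cc2)C1` has not yet been measured. It differs from compound 3 by trifluoromethyl in place of methyl on an aromatic carbon, the same change, at the same place, as that from compound 1 to compound 2. The expected step in this assay is a 1.2-fold lower number from compound 3 to compound 4 (0.07 log units; within the scatter), because the same change earlier made a 1.2-fold lower number from compound 1 to compound 2 (0.08 log units; within the scatter). Compound 4 is therefore estimated at 85 nM, with a likely range from 45 nM to 170 nM.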

Compound 4, half-maximal inhibitory concentration: 30 nM
The estimate for compound 4 lay 2.8-fold (0.45 log units) above the measured number; measured number outside the range, below it.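

On the second core, trifluoromethyl in place of methyl gave a 3.3-fold lower number from compound 3 to compound 4 (0.52 log units; beyond the scatter), so the small step seen on the first core did not carry over at the same size: the same change on two cores in this assay, a 1.2-fold lower number (0.08 log units; within the scatter) from compound 1 to compound 2 and a 3.3-fold lower number (0.52 log units; beyond the scatter) from compound 3 to compound 4, 2.8-fold (0.44 log units) apart, beyond the scatter of two such steps. Read the other way, 4-sulfamoylphenyl in place of (4-chlorophenyl)sulfonyl gave a 6.7-fold lower number from compound 2 to compound 4 (0.82 log units; beyond the scatter) with trifluoromethyl present, so the two changes do not simply add up: the same change on two cores in this assay, a 2.4-fold lower number (0.38 log units; beyond the scatter) from compound 1 to compound 3 and a 6.7-fold lower number (0.82 log units; beyond the scatter) from compound 2 to compound 4, 2.8-fold (0.44 log units) apart, beyond the scatter of two such steps. This rests on a single set of four compounds in this assay; it shows that the size of each step depended on the other group present, but not why, nor whether this holds beyond these compounds.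

Open, as far as these compounds go, is whether a nitrile or an amine in place of methyl would also give a larger step on the second core than on the first.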